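The source may hold more compounds than are shown below. What is called first, only, known or untested is meant among the compounds shown, and "the series" means these compounds.

Compound 1, `COc1cccc(C(=O)Nc2cc(-c3ccccc3)nn2-c2ccccc2)c1`, gives 1290 nM in an assay on HEK293 cells for displacement of a labelled ligand from metabotropic glutamate receptor 5 (Rattus norvegicus); on this read-out lower numbers stand for stronger inhibition and higher numbers for weaker inhibition.
Compound 2, `O=C(Nc1cc(-c2ccccc2)nn1-c1ccccc1)c1cccc([N+](=O)[O-])c1`, gives 2220 nM in this assay.
Compound 3, `NC(=O)c1ccc(C(=O)Nc2cc(-c3ccccc3)nn2-c2ccccc2)cc1`, gives in this assay only a limit, > 10000 nM.

All three share one core, an amide built on a carbonyl carbon, and differ only in the aryl group on that carbonyl carbon. Compound 3 stands at the weak end of what has been measured: its value is a limit of the assay, so no number is known for it, and it sits at the limit of > 10000 nM in this assay, at which 1 of the 3 values shown sits. The steps from the other two compounds to it were an at least 7.7-fold higher number from compound 1 to compound 3 (0.88 log units; beyond the scatter) and an at least 4.5-fold higher number from compound 2 to compound 3 (0.65 log units; beyond the scatter). Between compound 1 and compound 2 the step was a 1.7-fold higher number from compound 1 to compound 2 (0.24 log units; within the scatter).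

Compound 4, `COc1cc(OC)cc(C(=O)Nc2cc(-c3ccccc3)nn2-c2ccccc2)c1`, is not yet measured. From compound 3 to compound 4 the change is 3,5-dimethoxyphenyl in place of 4-carbamoylphenyl on a carbonyl carbon. For the measured compounds named here, the step bearing on it is the one from compound 1 to compound 3, since compound 4 carries the methoxy-bearing aryl of compound 1 with a second methoxy added, and that step was at least modest and beyond the scatter. Going the other way, from compound 3 to compound 4, a lower number is therefore expected, estimated as an at least 6.2-fold lower number from compound 3 to compound 4 (0.79 log units; beyond the scatter). For compound 4 in this assay the expected value is 1600 nM, with a range from 400 nM to 7000 nM.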

Compound 4, inhibition constant: > 10000 nM
Compound 4 gave a limit, no number (the forecaster's own chance of this, stated with the estimate: 20%); middle value at least 6.2-fold (0.79 log units) away from the limit.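

The new result shows that the aryl group on this carbonyl carbon does not need a carbamoyl to lose binding: in this assay, methoxy in place of hydrogen on an aromatic carbon of the aryl group of compound 1 gives an at least 7.7-fold higher number from compound 1 to compound 4 (0.88 log units; beyond the scatter), a step beyond the scatter from a change of one group. The 3,5-dimethoxyphenyl group also gives an at least 4.5-fold higher number from compound 2 to compound 4 (0.65 log units; beyond the scatter), so carrying methoxy on this aryl group does not by itself keep binding within reach of this assay, which compound 1 alone could not show. Compound 4 gives only a limit, as compound 3 does, so the step between them cannot be read, and the two can only be placed together at the weak end: the limit of > 10000 nM in this assay, at which 2 of the 4 values shown sit.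

On these data alone, how far compound 3 and compound 4 each lie past that limit remains open, so the 4-carbamoylphenyl and 3,5-dimethoxyphenyl groups cannot be ranked against each other. Also open, as far as these compounds go, is whether a fluorine, a methyl or a hydroxy in place of the added methoxy would stay near compound 1 or fall to the same limit.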